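A few compounds are considered here, and "the series" means these few. Any claim that something is new, unique, unknown or untested is made for them only; others in the source may bear on it.

Measured compounds and their values in an ADME assay (liver) for metabolic stability, with Liver microsome (Homo sapiens) as the target, read by LC-MS, using microsomes, with a stated time of 60 min, tested at 1 uM; on this read-out lower numbers stand for slow clearance and higher numbers for fast clearance:

compound 1, `Cc1cc(Br)ccc1C(=O)Nc1ccccn1`, gives 97 uL/min
compound 2, `Cc1ccccc1C(=O)Nc1cc(C#N)ccn1`, gives 82 uL/min
compound 3, `COc1ccc(NC(=O)c2ccccc2C)nc1`, gives 23 uL/min

All three share the same core, an amide that links a methyl-substituted benzene ring to a pyridine ring; they differ only in the small group placed on one ring or the other. Compound 2 stands second highest of the three numbers in this assay. Its nearest neighbour is compound 1, whose number is higher by a margin that falls within the usual scatter of repeated measurements, so the two cannot be told apart. Compound 3 sits furthest away, with a lower number that does lie beyond the scatter.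

Compound 4, `Cc1ccccc1C(=O)Nc1cc(Cl)ccn1`, has not yet been measured in this assay. It differs from compound 2 in one place: chloro in place of cyano on an aromatic carbon. Going by the values given here, nothing among the measured compounds shows this particular swap, so the expectation for compound 4 must lean on compound 2 itself, whose value of 82 uL/min is the starting point. The expected step is a 1.3-fold higher number from compound 2 to compound 4 (0.13 log units; within the scatter), small and inside the usual scatter, leaning slightly upward. Compound 4 is therefore estimated at 110 uL/min, with a range from 55 uL/min to 220 uL/min.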

Compound 4, intrinsic clearance in a liver preparation (reported as CLH), per the amount of preparation that the assay uses in the Liver microsome assay: 128 uL/min
For compound 4 the middle estimate is 1.2-fold (0.07 log units) below the measured one, within the range that was stated.
By their numbers in the Liver microsome assay, from the lowest: compound 3; then compounds 2, 1 and 4 (each within the scatter of the next).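

In the Liver microsome assay, chloro in place of cyano on the aromatic carbon opposite the ring nitrogen gives a 1.6-fold higher number from compound 2 to compound 4 (0.19 log units; within the scatter), so this single swap leaves the two clearance numbers impossible to tell apart. In a physicochemical assay for lipophilicity, read by HPLC, at pH 7.4 (on this read-out higher numbers stand for higher lipophilicity and lower numbers for lower lipophilicity), compound 2 gives 2.8 and compound 4 gives 3.4, so the same swap does register clearly on this second read-out. The earlier compounds shown here, with no pair among them differing in one place, could not show what this pair does, namely that at this position a measured rise in lipophilicity beyond the scatter can come without a clearance step beyond the scatter: the measured distribution coefficient of compound 2, 2.8, and of compound 4, 3.4, a number 0.60 log units higher (beyond the scatter).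

Still open, on these data alone, is whether a different group on this same carbon, such as an amine or a carboxylic acid, would give a clearance number clearly apart from those of compound 2 and compound 4. Also open, as far as these compounds go, is whether chloro in place of cyano would behave the same way elsewhere on the shared core, as this one pair speaks only for this position.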